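Series notes: a methoxy step carried onto a second core

The compounds below may be only part of what the source reports. "The series", "measured", "known", "first", "only" and "open" are said of these compounds alone.

Measured so far, in a functional assay on A549 cells (Homo sapiens) for antiproliferative activity, read by MTT assay, with a stated time of 48 h; a lower number here means a stronger inhibitor, a higher number a weaker inhibitor:
compound 1 `COc1ccc(/C=C/C(=O)Nc2nnc(-c3ccc(C)cc3)s2)cc1` gives 0.66 ug/mL;
compound 2 `Cc1ccc(-c2nnc(NC(=O)/C=C/c3ccccc3)s2)cc1` gives 1.38 ug/mL;
compound 3 `O=C(/C=C/c1ccccc1)Nc1nnc(-c2ccc(Cl)cc2)s1` gives 2.02 ug/mL.

The cores of compound 2 and compound 3 differ by chloro in place of methyl on an aromatic carbon, a step of a 1.5-fold higher number from compound 2 to compound 3 (0.17 log units; within the scatter). Within the core of compound 2, the change methoxy in place of hydrogen on an aromatic carbon gave a 2.1-fold lower number from compound 2 to compound 1 (0.32 log units; beyond the scatter).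

Compound 4 `COc1ccc(/C=C/C(=O)Nc2nnc(-c3ccc(Cl)cc3)s2)cc1` is not yet measured. It differs from compound 3 by methoxy in place of hydrogen on an aromatic carbon, the same change, at a place described in the same words. The same change within the core of compound 2 read a 2.1-fold lower number from compound 2 to compound 1 (0.32 log units; beyond the scatter). A step of similar size is expected here: a 2.0-fold lower number from compound 3 to compound 4 (0.31 log units; beyond the scatter). On that basis, compound 4 is expected to give about 1 ug/mL, between 0.5 ug/mL and 2 ug/mL.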

Compound 4, half-maximal inhibitory concentration: 1.38 ug/mL
Compound 4: middle estimate off by 1.4-fold (0.14 log units), on the low side, and the stated range covers the measured number.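

In this assay, methoxy in place of hydrogen on an aromatic carbon gave a 1.5-fold lower number from compound 3 to compound 4 (0.17 log units; within the scatter), and this reading stays close to the earlier one: the same change on two cores in this assay, a 2.1-fold lower number (0.32 log units; beyond the scatter) from compound 2 to compound 1 and a 1.5-fold lower number (0.17 log units; within the scatter) from compound 3 to compound 4, 1.4-fold (0.15 log units) apart, within the scatter of two such steps. Chloro in place of methyl on an aromatic carbon gave a 2.1-fold higher number from compound 1 to compound 4 (0.32 log units; beyond the scatter), which also stays close to its earlier reading: the same change on two cores in this assay, a 1.5-fold higher number (0.17 log units; within the scatter) from compound 2 to compound 3 and a 2.1-fold higher number (0.32 log units; beyond the scatter) from compound 1 to compound 4, 1.4-fold (0.15 log units) apart, within the scatter of two such steps. Each change therefore carried across the two cores shown without a gap beyond the scatter, but two cores per change, with one step of each pair within the scatter, fix no size for either step and say nothing about other cores.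

The compounds shown leave open whether an amine or a carboxylic acid in place of the methoxy would give a step of this kind. Also open, on these data alone, is whether the methoxy step holds with a group other than methyl or chloro, such as a nitrile, in the place those two occupy.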